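Swapping an Aromatic Ring for Bromo

This account rests on a few compounds, and the source may have more. Where it says the series, first, only, none or still open, it means among the compounds named here.

In a functional assay on MGC-803 cells (Homo sapiens) for antiproliferative activity, read by CellTiter-Glo, with a stated time of 72 h (a higher number here means a weaker inhibitor, a lower number a stronger inhibitor), compound 2 (`O=C(NO)c1ccc(/C=C/c2ccnc(-c3cccc(O)c3)c2)cc1`) gives 2100 nM. Compound 1 (`O=C(NO)c1cccc(/C=C/c2ccnc(-c3cc(F)ccc3O)c2)c1`) gives 2710 nM, which lies within the usual scatter of compound 2, so the two cannot be told apart. Compound 3 (`O=C(NO)c1ccc(/C=C/c2cccc(-c3cccc(O)c3)c2)cc1`) gives 8820 nM, a number beyond the scatter from compound 2 and so a weaker result. Compound 2 therefore stands level with compound 1 and clear of compound 3.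

Compound 4 (`O=C(NO)c1ccc(/C=C/c2ccnc(Br)c2)cc1`) has not been measured yet. It has bromo in place of 3-hydroxyphenyl on an aromatic carbon, next to the ring nitrogen: bromo in place of 3-hydroxyphenyl on an aromatic carbon. This swap removes a whole aromatic ring. Compound 1, compound 2 and compound 3 all keep a hydroxy-bearing ring, so the data offer no direct measure of what losing it does. Compound 3, at 8820 nM, shows how high the number climbs among these relatives, and this sets a rough guide for the upper side. The expected change is a moderate one towards a weaker inhibitor, with a 2.4-fold higher number from compound 2 to compound 4 (0.38 log units; beyond the scatter) as the estimated step. Compound 4 is expected at about 5000 nM, with an estimated range of 1500 nM to 18000 nM.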

Compound 4, half-maximal inhibitory concentration: > 10000 nM
Compound 4: a limit, no number (the forecaster's own chance of this, stated with the estimate: 15%); at least 2.0-fold (0.30 log units) between middle value and limit.
By their numbers in this assay, from the lowest: compounds 2 and 1 (each within the scatter of the next); then compound 3. At a limit, above all of these: compound 4.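

In this assay, compound 4 gives > 10000 nM, which is a limit of the assay and not a number. Going by these compounds alone, every earlier compound keeps a hydroxy-bearing ring, so this is the first direct view of losing that ring: bromo in place of 3-hydroxyphenyl, on an aromatic carbon next to the ring nitrogen, gives an at least 4.7-fold higher number from compound 2 to compound 4 (0.67 log units; beyond the scatter). The result shows that a single bromine cannot stand in for the whole 3-hydroxyphenyl group at this place, but the step gives only a lower bound on the loss, and its true size stays unknown because the reading stops at a limit: the limit of > 10000 nM in this assay, at which 1 of the 4 values shown sits.

Going by these compounds, what stays open is whether the aromatic ring or its hydroxy group matters more, and a plain phenyl group at this carbon, keeping the ring without the hydroxy, would separate the two. On these data alone, it is also open whether the loss belongs to bromo in particular, which a small group such as an amine or a methyl on the same carbon could help to test.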